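This account rests on a few compounds, and the source may have more. Where it says the series, first, only, none or still open, it means among the compounds named here.

Compound 2 `Nn1nc(-c2nccs2)c2sccc2c1=O` stands highest of the two numbers measured in an assay on CHO cells for displacement of a labelled ligand from adenosine receptor A1 (Homo sapiens), read by scintillation counting, with a stated time of 90 min; a lower number here means a stronger inhibitor, a higher number a weaker inhibitor. Compound 1 `CCn1nc(-c2nccs2)c2sccc2c1=O` is the nearest point: in this assay compound 1 gives 113 nM, while in this assay compound 2 gives 2870 nM. Going by the values given here, the one measured step, a 25-fold higher number from compound 1 to compound 2 (1.40 log units; beyond the scatter), goes with amino in place of ethyl on an aromatic nitrogen. Compound 3 `O=c1[nH]nc(-c2nccs2)c2sccc12` differs from compound 2 by hydrogen in place of amino on an aromatic nitrogen. Among the compounds with values here, no measured step covers removal of the amino to a bare hydrogen, so the step from compound 1 to compound 2 bears on it only indirectly: it shows that what sits on that ring nitrogen moves the number strongly, with ethyl giving the lower number and amino the higher one. Hydrogen is neither, and the number for compound 3 is therefore expected to fall between the two measured values rather than beyond them, with wide uncertainty. Compound 3 is expected to give about 1200 nM in this assay, within 250 nM to 6000 nM. This corresponds to an expected step of a 2.4-fold lower number from compound 2 to compound 3 (0.38 log units; beyond the scatter).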

Compound 3, inhibition constant: 1150 nM
Beside the measured number, compound 3's estimate is 1.0-fold (0.02 log units) above it; the range from low to high includes it.
By their numbers in this assay, from the lowest: compound 1; then compound 3; then compound 2.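

In this assay, hydrogen on the aromatic nitrogen gives the series a reference point that the ethyl and amino compounds alone could not provide, and the loss of amino goes with a 2.5-fold lower number from compound 2 to compound 3 (0.40 log units; beyond the scatter). Hydrogen in place of ethyl goes with a 10-fold higher number from compound 1 to compound 3 (1.01 log units; beyond the scatter), so relative to hydrogen, ethyl and amino move the number in opposite directions, ethyl to a lower number and amino to a higher one, and this position does not simply favour any group over hydrogen. Nothing at hand accounts for either step.

From the compounds shown here alone, whether a methyl or propyl group on the same nitrogen would extend the move from hydrogen to ethyl remains open, as does whether a chain ending in a hydroxyl or an amine would keep the lower number seen with ethyl. Going by these compounds, all three compounds also carry the 1,3-thiazol-2-yl group on the shared core, so it remains open whether these steps would hold with another group there, such as phenyl.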